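Removing one chloro group: cytotoxicity in human kidney cells

The source may hold more compounds than are shown below. What is called first, only, known or untested is meant among the compounds shown, and "the series" means these compounds.

Compound 1, `CC(=O)c1ccc(NC(=O)Nc2cc(C)nc3ccccc23)cc1`. In an ADME assay on HEK293 cells (Homo sapiens) for cytotoxicity, with a stated time of 72 h (a lower number here means that less compound is needed, a higher number that more compound is needed for the effect), compound 1 gives > 25000 nM, which is a limit of the assay rather than a number.
Compound 2, `COc1ccc(NC(=O)Nc2cc(C)nc3ccccc23)cc1OC`. In this assay compound 2 gives > 25000 nM, again a limit.
Compound 3, `Cc1cc(NC(=O)Nc2cc(Cl)cc(Cl)c2)c2ccccc2n1`. In this assay compound 3 gives > 25000 nM, also a limit.

Compound 3 therefore stands where every measured compound stands: at the limit of > 25000 nM in this assay, at which 3 of the 3 values shown sit. Going by the values given here, none of the three shows a number for cytotoxicity, so no step between measured compounds can be sized, and there is no evidence of order among them.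

The unmeasured compound 4, `Cc1cc(NC(=O)Nc2cccc(Cl)c2)c2ccccc2n1`, differs from compound 3 in one place: hydrogen in place of chloro on an aromatic carbon.

With all three measured compounds sitting at the limit, no shift beyond the scatter is expected from this change; the step that the limit leaves unreadable from compound 3 to compound 4 is an estimate of essentially no movement. Compound 4 is expected to give 30000 nM, within the range 15000 nM to 100000 nM, most likely reported again as a limit.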

Compound 4, half-maximal effective concentration: 21000 nM
The estimate for compound 4 lay 1.4-fold (0.15 log units) above the measured number, and the stated range covers the measured number.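

Going by these compounds alone, compound 4 is the only compound here that gives a real number rather than a limit in this assay, at 21000 nM, so one side of this change now has a measured value. Replacing chloro with hydrogen on this aromatic carbon gives an at least 1.1-fold lower number from compound 3 to compound 4 (0.07 log units; that floor lies within the scatter), so removing this one chlorine atom is not shown to shift the cytotoxicity reading beyond the usual scatter. That step is only a floor, not a measured size, and most of the series still gives no number: the limit of > 25000 nM in this assay, at which 3 of the 4 values shown sit.

The compounds shown leave open how far the true value of compound 3 lies from that of compound 4. They also leave open how the reading would respond to an amine or a carboxylic acid at this same position.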